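Methylsulfanyl to chloro on the shared core

The source may hold more compounds than are shown below. What is called first, only, known or untested is meant among the compounds shown, and "the series" means these compounds.

Compound 1 `CSc1nc(N)c2ncn([C@H]3[C@H](O)[C@H](O)[C@@]4(COP(=O)(O)OP(=O)(O)O)C[C@@H]34)c2n1` gives 0.88 nM in an assay on cell membranes for activation of P2Y purinoceptor 1 (Meleagris gallopavo); on this read-out higher numbers stand for an effect only at larger amounts of compound and lower numbers for an effect already at smaller amounts. Compound 2 `CSc1nc(N)c2ncn([C@H]3[C@H](O)[C@H](O)[C@@]4(COP(=O)(O)O)C[C@@H]34)c2n1` gives 1190 nM in this assay, the highest of the two numbers; the step of a 1400-fold higher number from compound 1 to compound 2 (3.13 log units; beyond the scatter) is the only measured one in the series. Compound 3 `Nc1nc(Cl)nc2c1ncn2[C@H]1[C@H](O)[C@H](O)[C@@]2(COP(=O)(O)O)C[C@@H]12` differs from compound 2 by chloro in place of methylsulfanyl on an aromatic carbon. Going by the values given here, no measured step touches this change, so nothing fixes its size or direction; the estimate therefore stays near compound 2 with a wide range. Compound 3 is expected to give 2500 nM in this assay, between 500 nM and 12000 nM, meaning an estimated step of a 2.1-fold higher number from compound 2 to compound 3 (0.32 log units; beyond the scatter).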

Compound 3, half-maximal effective concentration: 3900 nM
Estimate against measurement, compound 3: 1.6-fold (0.19 log units) below, within the range that was stated.
By their numbers in this assay, from the lowest: compound 1; then compound 2; then compound 3.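

Chloro in place of methylsulfanyl on this aromatic carbon, between two ring nitrogen atoms, gives a 3.3-fold higher number from compound 2 to compound 3 (0.52 log units; beyond the scatter) in this assay, so the position takes this exchange with only a modest shift. That shift is small beside a 1400-fold higher number from compound 1 to compound 2 (3.13 log units; beyond the scatter), the change on the oxygen. No available evidence accounts for the direction of the shift.

Open, going by these compounds, is whether chloro gives a similar step on the longer phosphate chain of compound 1. Also open, on these data alone, is how an amine or ethylsulfanyl on this carbon would compare.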